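Amino Substitution on a Furanyl Nucleoside Core

A few compounds are considered here, and "the series" means these few. Any claim that something is new, unique, unknown or untested is made for them only; others in the source may bear on it.

Among the measured compounds shown here, in a functional assay on HeLa S3 cells (Homo sapiens) for antiproliferative activity, read by XTT assay, with a stated time of 72 h (a higher number here means a weaker inhibitor, a lower number a stronger inhibitor), compound 3 `O=c1[nH]cnc2c1c(-c1ccco1)cn2[C@@H]1O[C@H](CO)[C@@H](O)[C@H]1O` gives 5780 nM, the only actual number among the three values shown and the lowest of them. Compound 1 `O=c1[nH]cnc2c1c(-c1cccs1)cn2[C@@H]1O[C@H](CO)[C@@H](O)[C@H]1O` reaches only the limit > 20000 nM. Compound 2 `O=c1[nH]cnc2c1c(-c1ccsc1)cn2[C@@H]1O[C@H](CO)[C@@H](O)[C@H]1O` likewise reaches only the limit > 20000 nM. The measured steps concern the aryl group alone: an at least 3.4-fold lower number from compound 1 to compound 3 (0.53 log units; beyond the scatter) and an at least 3.4-fold lower number from compound 2 to compound 3 (0.53 log units; beyond the scatter), both resting on (the limit of > 20000 nM in this assay, at which 2 of the 3 values shown sit). Compound 4 `Nc1nc2c(c(-c3ccco3)cn2[C@@H]2O[C@H](CO)[C@@H](O)[C@H]2O)c(=O)[nH]1` instead alters the core: amino in place of hydrogen on an aromatic carbon. For the measured compounds named here, no measured step touches this change, so its size and direction are open, and the expectation leans on compound 3 itself. Compound 4 is therefore estimated at 8000 nM, between 2500 nM and 18000 nM. The expected step is a 1.4-fold higher number from compound 3 to compound 4 (0.14 log units; within the scatter), within the scatter.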

Compound 4, half-maximal inhibitory concentration: > 20000 nM
Compound 4 was reported as a limit; the forecaster's own chance of this, stated with the estimate: 30%; middle value at least 2.5-fold (0.39 log units) from the limit.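

In this assay, among the compounds shown here, the first change to the core, amino in place of hydrogen on the aromatic carbon between two ring nitrogen atoms, brings an at least 3.4-fold higher number from compound 3 to compound 4 (0.53 log units; beyond the scatter), so substitution at this position costs the one measurable value. Compound 4 gives > 20000 nM, which is a limit and not a number, so only a lower bound on the step can be read. Furan-2-yl alone therefore does not secure activity once the core changes: the limit of > 20000 nM in this assay, at which 3 of the 4 values shown sit.

From the compounds shown here alone, whether a methyl, methoxy or chloro group on this carbon would keep a measurable value remains open. So does the effect of amino on compound 1 and compound 2, which already sit at the limit.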